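Hydrazone series on the shared core: styryl analogue

This account rests on a few compounds, and the source may have more. Where it says the series, first, only, none or still open, it means among the compounds named here.

Measured so far in a functional assay on MCF7 cells (Homo sapiens) for cytotoxicity, read by MTT assay, with a stated time of 48 h; a higher number here means a weaker inhibitor, a lower number a stronger inhibitor:
compound 1 `O=C(CSc1nnc(-c2ccncc2)o1)N/N=C/c1ccc(F)cc1` — 13500 nM
compound 2 `COc1cccc(/C=N/NC(=O)CSc2nnc(-c3ccncc3)o2)c1` — 13800 nM
compound 3 `O=C(CSc1nnc(-c2ccncc2)o1)N/N=C/c1ccccc1O` — 4750 nM

All three share one core and differ only in the group on the carbon with a double bond to nitrogen. Compound 1 gives the second highest number of the three. Its nearest neighbour is compound 2, with a 1.0-fold higher number from compound 1 to compound 2 (0.01 log units; within the scatter); its furthest is compound 3, with a 2.8-fold lower number from compound 1 to compound 3 (0.45 log units; beyond the scatter). The step of a 2.9-fold lower number from compound 2 to compound 3 (0.46 log units; beyond the scatter) is of similar modest size, so the 2-hydroxyphenyl compound stands apart from the other two.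

Compound 4 `O=C(CSc1nnc(-c2ccncc2)o1)N/N=C/C=C/c1ccccc1` is not yet measured. Relative to compound 1 the change is 2-phenylethenyl in place of 4-fluorophenyl on a carbon with a double bond to nitrogen. Among the measured compounds shown here, no measured step exchanges the aromatic ring for a group carrying a double bond outside aromatic rings, so none bears directly on this change. The steps in hand swap one substituted phenyl for another: one stays within the scatter, the other two are modest. On that basis the expected change is small, a 1.1-fold lower number from compound 1 to compound 4 (0.05 log units; within the scatter), with no firm direction. Compound 4 is estimated at 12000 nM, in the range 5000 nM to 30000 nM.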

Compound 4, half-maximal inhibitory concentration: 10800 nM
Compound 4: middle estimate off by 1.1-fold (0.05 log units), on the high side, within the range that was stated.
By their numbers in this assay, from the lowest: compound 3; then compounds 4, 1 and 2 (each within the scatter of the next).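

In this assay, a group carrying a double bond outside aromatic rings is accepted on the carbon with a double bond to nitrogen without a change beyond the scatter: 2-phenylethenyl in place of 4-fluorophenyl gives a 1.3-fold lower number from compound 1 to compound 4 (0.10 log units; within the scatter), and 2-phenylethenyl in place of 3-methoxyphenyl gives a 1.3-fold lower number from compound 2 to compound 4 (0.11 log units; within the scatter). Among the compounds shown here, compounds 1, 2 and 4 therefore form one group in this assay, although the new group is not a phenyl ring attached directly to that carbon, and 2-hydroxyphenyl remains the only group of the four that stands apart, with a 2.3-fold higher number from compound 3 to compound 4 (0.36 log units; beyond the scatter). No measurement in hand accounts for the separate position of compound 3 or for the flat values of the other three.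

Still open, going by these compounds, is whether a hydroxy group placed on the phenyl ring of the 2-phenylethenyl group would bring the number down to the level of compound 3, or whether that result is confined to 2-hydroxyphenyl. Also open, on these data alone, is how this position responds to an amine, a carboxylic acid or a longer chain with further double bonds, since all four groups so far are neutral and carry one aromatic ring of carbon only.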